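Ethyl to methoxy: 4-ethylphenyl to 4-methoxyphenyl

The compounds below may be only part of what the source reports. "The series", "measured", "known", "first", "only" and "open" are said of these compounds alone.

In a functional assay on HCT-116 cells (Homo sapiens) for antiproliferative activity, read by CCK-8 assay, with a stated time of 72 h (on this read-out higher numbers stand for weaker inhibition and lower numbers for stronger inhibition), compound 1 (`Nc1ccccc1NC(=O)c1ccc(COc2ccc([N+](=O)[O-])cc2)cc1`) gives > 32000 nM as a limit of the assay and not a number. Going by the values given here, compound 2 (`Nc1ccccc1NC(=O)c1ccc(COc2ccc(Cl)cc2)cc1`) gives 17300 nM and compound 3 (`CCc1ccc(OCc2ccc(C(=O)Nc3ccccc3N)cc2)cc1`) gives 4830 nM as the lowest number so far. The closest gap to it is modest, a 3.6-fold lower number from compound 2 to compound 3 (0.55 log units; beyond the scatter) in size, while an at least 6.6-fold lower number from compound 1 to compound 3 (0.82 log units; beyond the scatter) is at least modest. Compound 4 (`COc1ccc(OCc2ccc(C(=O)Nc3ccccc3N)cc2)cc1`) has methoxy in place of ethyl on an aromatic carbon. Among the compounds with values here, no measured step links these two groups directly. Since compound 2 lies only a 3.6-fold lower number from compound 2 to compound 3 (0.55 log units; beyond the scatter) away, a smaller rise is expected, within the scatter. The estimated step is a 1.4-fold higher number from compound 3 to compound 4 (0.16 log units; within the scatter) as a working figure. The expected value for compound 4 is 7000 nM (expected range 2800 nM to 17000 nM).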

Compound 4, half-maximal inhibitory concentration: 2020 nM
Beside the measured number, compound 4's estimate is 3.5-fold (0.54 log units) above it, and the stated range ends above it.
By their numbers in this assay, from the lowest: compound 4; then compound 3; then compound 2. At a limit, above all of these: compound 1.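

Going by a 2.4-fold lower number from compound 3 to compound 4 (0.38 log units; beyond the scatter) methoxy, para to a large group, replaces ethyl as the group with the lowest number in this assay at this place. Both groups count 2 heavy atoms, so that count alone does not set the number, and chloro lies further off, with an 8.6-fold lower number from compound 2 to compound 4 (0.93 log units; beyond the scatter) as the gap. Compound 1 stands at a limit of the assay and not at a number, so an at least 15-fold lower number from compound 1 to compound 4 (1.19 log units; beyond the scatter) gives only a floor: the limit of > 32000 nM in this assay, at which 1 of the 4 values shown sits.

As far as these compounds go, whether ethoxy, an amine or a hydroxyl at this place would give a lower number stays open.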